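The compounds below may be only part of what the source reports. "The series", "measured", "known", "first", "only" and "open" are said of these compounds alone.

Measured in a functional assay on HepG2 cells (Homo sapiens) for inhibition, read by MTT assay, with a stated time of 120 h; a lower number here means a stronger inhibitor, a higher number a weaker inhibitor:
compound 1 `CC(NC(=O)/C=C/c1ccc(NC(=O)Nc2ccc(Cl)c(C(F)(F)F)c2)cc1)c1ccccc1`: 12200 nM
compound 2 `CC(NC(=O)c1ccc(-c2ccc(NC(=O)Nc3cc(C(F)(F)F)ccc3Cl)cc2)cc1)c1ccccc1`: 18400 nM
compound 3 `CC1CN(C(=O)/C=C/c2ccc(NC(=O)Nc3ccc(Cl)c(C(F)(F)F)c3)cc2)CC(C)O1`: 45900 nM

Compound 1 and compound 3 sit on one core and differ by 2,6-dimethylmorpholin-4-yl in place of (1-phenylethyl)amino on a carbonyl carbon; this gives a 3.8-fold higher number from compound 1 to compound 3 (0.58 log units; beyond the scatter). Compound 2 rests on a second core; the difference between the two cores is not broken down here. The values of compound 2 and compound 1 lie within the scatter of each other.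

Compound 4 `CC1CN(C(=O)c2ccc(-c3ccc(NC(=O)Nc4cc(C(F)(F)F)ccc4Cl)cc3)cc2)CC(C)O1` is the counterpart of compound 2 carrying (2,6-dimethylmorpholin-4-yl in place of (1-phenylethyl)amino on a carbonyl carbon). This is the same kind of change as that in compound 3, not the same: in compound 4 the carbonyl carbon's other neighbour is an aromatic carbon, in compound 3 a double-bonded chain carbon. Among the compounds with values here, the only measured reading of the change is a 3.8-fold higher number from compound 1 to compound 3 (0.58 log units; beyond the scatter), and the expectation for compound 4 rests on it. For compound 4 the expected step is a 3.3-fold higher number from compound 2 to compound 4 (0.51 log units; beyond the scatter). The estimate for compound 4 is 60000 nM, with a range of 25000 nM to 150000 nM.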

Compound 4, half-maximal inhibitory concentration: > 50000 nM
Compound 4: no number, only a limit; the forecaster's own chance of this, stated with the estimate: 20%; the middle value is on the limit's open side.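

In this assay compound 4 gives > 50000 nM, which is a limit of the assay and not a number. Putting 2,6-dimethylmorpholin-4-yl in place of (1-phenylethyl)amino on the carbonyl carbon gives an at least 2.7-fold higher number from compound 2 to compound 4 (0.43 log units; beyond the scatter), so the change moves the number in the same direction on both cores: the same change on two cores in this assay, a 3.8-fold higher number (0.58 log units; beyond the scatter) from compound 1 to compound 3 and an at least 2.7-fold higher number (0.43 log units; beyond the scatter) from compound 2 to compound 4; the limit leaves it open whether they differ. The size of the step on the core of compound 2 is not shown, so this is agreement in direction on two pairs only and no measure of how well the change carries over.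

Open, from the compounds shown here alone, is how a carboxylic acid or an unsubstituted morpholin-4-yl on the same carbonyl carbon would read on either core. The compounds shown also leave open which part of the 2,6-dimethylmorpholin-4-yl group goes with the step, the two methyl groups or the ring itself.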